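This account rests on a few compounds, and the source may have more. Where it says the series, first, only, none or still open, it means among the compounds named here.

Compound 2 `COC(=O)c1cccc(NC(=O)c2cccc(-c3cc(C(=O)Nc4ccncc4F)ccc3CN)c2)c1F` gives 1.2 nM in an assay on cells for inhibition of Rho-associated protein kinase 2 (Homo sapiens), read by radiometric assay and 33P incorporation, in the presence of a further agent that is not named here (a lower number here means a stronger inhibitor, a higher number a weaker inhibitor), and holds the higher of the two numbers recorded so far, though its neighbour compound 1 `NCc1ccc(C(=O)Nc2ccncc2F)cc1-c1cccc(NC(=O)c2ccc(C(=O)O)cc2)c1`, with 1 nM in this assay, sits within the scatter of it. Compound 3 `NCc1ccc(C(=O)Nc2ccncc2F)cc1-c1cccc(C(=O)Nc2ccccc2)c1` has not been measured; it differs from compound 2 by phenyl in place of 2-fluoro-3-(methoxycarbonyl)phenyl on an amide-type nitrogen. Going by the values given here, no measured pair shows this change, so the step is a guess: since compound 2 sits at 1.2 nM, a modest loss is expected, with the step from compound 2 to compound 3 estimated at a 2.5-fold higher number from compound 2 to compound 3 (0.40 log units; beyond the scatter). For compound 3 the expected value is 3 nM, ranging from 1 nM to 10 nM.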

Compound 3, half-maximal inhibitory concentration: < 1 nM
Compound 3: only a limit was reported; the forecaster's own chance of this, stated with the estimate: 2%; middle value at least 3.0-fold (0.47 log units) away from the limit.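

Compound 3 is reported only as a limit, < 1 nM. On this amide-type nitrogen, phenyl in place of 2-fluoro-3-(methoxycarbonyl)phenyl gives an at least 1.2-fold lower number from compound 2 to compound 3 (0.07 log units; that floor lies within the scatter). Neither the fluoro nor the methoxycarbonyl substituent is needed for a number at this level in this assay. The full size of the step stays open because the reading stops at the limit: the limit of < 1 nM in this assay, at which 1 of the 3 values shown sits.

Phenylcarbamoyl in place of ((4-carboxyphenyl)carbonyl)amino on an aromatic carbon gives a number no higher from compound 1 to compound 3 (the limit leaves the size open). On these data alone, whether cyclohexyl or benzyl on the amide-type nitrogen would keep the number at this level remains open.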